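The compounds below may be only part of what the source reports. "The series", "measured", "known", "first", "only" and "open" are said of these compounds alone.

Three compounds share one core and differ only in the aryl group on the carbon with a double bond to nitrogen. In a functional assay on A549 cells (Homo sapiens) for cytotoxicity, read by MTT assay, with a stated time of 72 h (on this read-out higher numbers stand for weaker inhibition and lower numbers for stronger inhibition), compound 1 `CN(C)CCn1cnnc1-c1cc(Oc2ccc(NC(=O)N/N=C/c3ccc(O)c(Br)c3)cc2F)ccn1` gives 1370 nM. Compound 2 `CN(C)CCn1cnnc1-c1cc(Oc2ccc(NC(=O)N/N=C/c3ccc(F)cc3)cc2F)ccn1` gives 1790 nM. Compound 3 `CN(C)CCn1cnnc1-c1cc(Oc2ccc(NC(=O)N/N=C/c3cccc(Cl)c3Cl)cc2F)ccn1` gives 1090 nM, the lowest number shown, though each of its steps to the others stays within the scatter: a 1.3-fold lower number from compound 1 to compound 3 (0.10 log units; within the scatter) and a 1.6-fold lower number from compound 2 to compound 3 (0.22 log units; within the scatter), and likewise a 1.3-fold higher number from compound 1 to compound 2 (0.12 log units; within the scatter). Compound 4 `CN(C)CCn1cnnc1-c1cc(Oc2ccc(NC(=O)N/N=C/c3cccc(O)c3)cc2F)ccn1` carries 3-hydroxyphenyl in place of 2,3-dichlorophenyl on a carbon with a double bond to nitrogen. All three measured steps exchange this same aryl group, one of them swapping 3-bromo-4-hydroxyphenyl for 4-fluorophenyl and two of them introducing 2,3-dichlorophenyl, and none moves the number beyond the scatter. Among the measured compounds shown here, no measured step introduces 3-hydroxyphenyl, so the change itself is untested. The expectation for compound 4 is therefore no step beyond the scatter, a 1.3-fold higher number from compound 3 to compound 4 (0.11 log units; within the scatter). In this assay compound 4 is estimated at 1400 nM, with a range from 600 nM to 3200 nM.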

Compound 4, half-maximal inhibitory concentration: > 100000 nM
Compound 4: no number, only a limit (the forecaster's own chance of this, stated with the estimate: 2%); middle value at least 71-fold (1.85 log units) away from the limit.
By their numbers in this assay, from the lowest: compounds 3, 1 and 2 (each within the scatter of the next). At a limit, above all of these: compound 4.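

In this assay compound 4 gives no number, only a limit of the assay: the limit of > 100000 nM in this assay, at which 1 of the 4 values shown sits.

The aryl group on the carbon with a double bond to nitrogen, which moved the number only within the scatter among compounds 1, 2 and 3, now carries large steps: an at least 91-fold higher number from compound 3 to compound 4 (1.96 log units; beyond the scatter), an at least 55-fold higher number from compound 2 to compound 4 (1.74 log units; beyond the scatter) and an at least 72-fold higher number from compound 1 to compound 4 (1.86 log units; beyond the scatter). This position therefore does not accept every aryl group, and a hydroxyl on the ring does not by itself bring the limit, since compound 1, with 3-bromo-4-hydroxyphenyl, goes against that reading.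

Still open, going by these compounds, is whether the step follows the hydroxyl of 3-hydroxyphenyl or the absence of any halogen on the ring. A plain phenyl or a 3-methoxyphenyl group would separate these two readings, and an amine or a carboxylic acid on this ring remains an open question.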